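A few compounds are considered here, and "the series" means these few. Any claim that something is new, unique, unknown or untested is made for them only; others in the source may bear on it.

Measured so far:
compound 1 `COc1cccc(OC)c1C(=O)Nc1c[nH]nc1C(=O)NCCCOC(C)C`, > 50000 nM
compound 2 `CO[C@H]1CC[C@H](NC(=O)c2n[nH]cc2NC(=O)c2cc3ccccc3o2)CC1`, 800 nM
compound 3 `CO[C@H]1CC[C@H](NC(=O)c2n[nH]cc2NC(=O)c2ccccc2)CC1`, 800 nM

As far as these compounds go, in an ADME assay on MRC5 cells (Homo sapiens) for inhibition, with a stated time of 72 h (a higher number here means that more compound is needed for the effect, a lower number that less compound is needed), compound 1 gives only a limit, > 50000 nM, so its actual value is unknown. Compound 4 `COc1cccc(OC)c1C(=O)Nc1c[nH]nc1C(=O)NC1CC2CCC1C2` differs from compound 1 by a group of 7 heavy atoms (7 carbon; 2 five-membered non-aromatic rings of carbon only) in place of a group of 7 heavy atoms (6 carbon, 1 oxygen; no ring), on an amide-type nitrogen. For the measured compounds named here, the only measured step, no change at the digits printed from compound 2 to compound 3 (within the scatter), alters the group on the carbonyl carbon and so does not bear on this change. Compound 2 gives 800 nM and compound 3 gives 800 nM, but each differs from compound 1 in more than one place. Going by the values given here, with no comparable step available, compound 4 is estimated at 15000 nM, with a wide range from 1500 nM to 50000 nM. The step of an at least 3.3-fold lower number from compound 1 to compound 4 (0.52 log units; beyond the scatter) is therefore expected with little confidence, and a limit is again quite possible.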

Compound 4, half-maximal effective concentration: > 50000 nM
Compound 4 ended at the assay's limit; the forecaster's own chance of this, stated with the estimate: 45%; middle value at least 3.3-fold (0.52 log units) away from the limit.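

Compound 1 and compound 4 both end at a limit, so no step between them can be read in this assay: the limit of > 50000 nM in this assay, at which 2 of the 4 values shown sit.

As far as these compounds go, whether replacing the 3-isopropoxypropyl group with the carbon-only ring group changes the value at all remains open.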